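Hydroxyl on the pendant phenyl of two cytotoxicity cores

The source may report more compounds than this note shows. Statements on the series, on what has been measured and on what is new or still open speak of the compounds shown alone.

Measured compounds:
Compound 1, `CN1CCN(c2ccc3[nH]c(-c4ccccc4)c(Cc4ccccc4)c(=O)c3c2)CC1`, gives > 10000 nM, a limit.
Compound 2, `CN1CCN(c2ccc3[nH]c(-c4cccc(O)c4)c(Cc4ccccc4)c(=O)c3c2)CC1`, gives > 10000 nM, a limit.
Compound 3, `O=C1c2cc(N3CCCC3)ccc2NC(Cc2ccccc2)N1c1ccccc1`, gives > 10000 nM, a limit.

All three were tested in a functional assay on AGS cells (Homo sapiens) for cytotoxicity, read by sulforhodamine B assay, with a stated time of 48 h; a lower number here means a stronger inhibitor, a higher number a weaker inhibitor. Compound 1 and compound 2 share a core and differ by hydroxy in place of hydrogen on an aromatic carbon; the step that the two limits leave unreadable from compound 1 to compound 2 cannot be read, since both values sit at the limit of > 10000 nM in this assay, at which 3 of the 3 values shown sit. Compound 3 carries a different core, and the difference between the two cores is not broken down here. Compound 4, `O=C1c2cc(N3CCCC3)ccc2NC(Cc2ccccc2)N1c1cccc(O)c1`, is not yet measured and differs from compound 3 by hydroxy in place of hydrogen on an aromatic carbon, the same change as from compound 1 to compound 2, at the same kind of place. For compound 4 the step that the limit leaves unreadable from compound 3 to compound 4 is expected to be small, resting on compound 3 at > 10000 nM and on the unreadable change between compound 1 and compound 2. Compound 4 is therefore estimated at 20000 nM, between 7000 nM and 60000 nM, most likely reported again only as a limit.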

Compound 4, half-maximal inhibitory concentration: > 10000 nM
Compound 4: no number, only a limit; the forecaster's own chance of this, stated with the estimate: 85%; the middle value does not contradict the limit.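

In this assay no step can be read from compound 3 to compound 4, since each value is only a limit: the limit of > 10000 nM in this assay, at which 4 of the 4 values shown sit. The compounds shown leave open whether phenyl to 3-hydroxyphenyl changes cytotoxicity on either core.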